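Changing the Aromatic Ring on the Carbonyl Carbon

This account rests on a few compounds, and the source may have more. Where it says the series, first, only, none or still open, it means among the compounds named here.

Measured so far:
compound 1, `COC(=O)CCNC(=O)[C@@H]1O[P@](=O)(OCOC(=O)c2scnc2C(C)(C)C)OCC1(C)C`, 0.44 h
compound 2, `COC(=O)CCNC(=O)[C@@H]1O[P@@](=O)(OCOC(=O)c2scnc2C(C)(C)C)OCC1(C)C`, > 1 h

In an ADME assay on blood (Homo sapiens) for pharmacokinetics (a lower number here means that the compound disappears faster, a higher number that the compound lasts longer), compound 1 gives 0.44 h. Among the measured compounds shown here, this is the only plain number available in the set. For compound 2 the result in this assay is recorded only as a limit of the measurement, > 1 h. For the measured compounds named here, the single measured step, an at least 2.2-fold higher number from compound 1 to compound 2 (0.35 log units; beyond the scatter), is tied to the fact that (the fact that compounds 1 and 2 differ only in the configuration as drawn); the two compounds share every atom and bond.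

Compound 3, `COC(=O)CCNC(=O)[C@@H]1O[P@](=O)(OCOC(=O)c2cc(C(C)(C)C)n[nH]2)OCC1(C)C`, has not yet been measured in this assay. Compared with compound 1 the change is 3-(tert-butyl)-1H-pyrazol-5-yl in place of 4-(tert-butyl)-1,3-thiazol-5-yl on a carbonyl carbon. The configuration at the phosphorus stays as drawn in compound 1. Going by the values given here, no measured step swaps one aromatic ring for another, so the step from compound 1 to compound 2, a change of configuration only, gives no guide here, and nothing indicates a direction. The expected outcome is therefore a step that stays within the scatter, a 1.1-fold higher number from compound 1 to compound 3 (0.06 log units; within the scatter). Compound 3 is estimated at 0.5 h in this assay, within a range from 0.2 h to 1.5 h that leaves room for a shift either way.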

Compound 3, half-life: < 0.16 h
Compound 3: only a limit was reported; the forecaster's own chance of this, stated with the estimate: 20%; at least 3.1-fold (0.49 log units) between middle value and limit.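

The aromatic ring on this carbonyl carbon clearly matters in this assay: 3-(tert-butyl)-1H-pyrazol-5-yl in place of 4-(tert-butyl)-1,3-thiazol-5-yl gives an at least 2.7-fold lower number from compound 1 to compound 3 (0.43 log units; beyond the scatter), whereas the earlier pair showed only a change of configuration at the phosphorus. For compound 3, the recorded value of < 0.16 h is a limit of the assay and not a number. The two groups have the same number of heavy atoms, and each is a five-membered aromatic ring with 2 hetero atoms and a tert-butyl group, yet they differ in a nitrogen in place of sulfur and in the hydrogen-bond donor that only the entering group has, and nothing measured here shows which of these differences matters.

A ring with a methyl group in place of the hydrogen on the pyrazole nitrogen, or a phenyl ring carrying a tert-butyl group, would help separate these differences. Also open, from the compounds shown here alone, is whether the phosphorus configuration has the same effect when 3-(tert-butyl)-1H-pyrazol-5-yl sits on the carbonyl carbon.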